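Bromo in place of hydrogen on compound 1

The compounds below may be only part of what the source reports. "The series", "measured", "known", "first", "only" and "open" are said of these compounds alone.

Among the measured compounds shown here, compound 1 `COc1cc(OC)c(C(=O)/C=C/c2ccccc2)c(OC)c1` is the only member of the series with a number to its name. In a functional assay on Huh-7 cells (Homo sapiens), read by fluorescence and BrdU incorporation, with a stated time of 48 h, tested at 10 uM (on this read-out higher numbers stand for a weaker effect at the one concentration tested and lower numbers for a stronger effect), compound 1 gives 45%. Compound 2 `COc1cc(O)c(C(=O)/C=C/c2ccccc2OC)c(OC)c1` is the only other measured entry; in this assay compound 2 is reported as "not active" (no number reported), with no number given. For the measured compounds named here, no two measured compounds differ in one place, so no step between measured compounds is available, and compound 1 stands alone as the point of reference.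

Compound 3 `COc1cc(OC)c(C(=O)/C=C/c2ccc(Br)cc2)c(OC)c1` differs from compound 1 by bromo in place of hydrogen on an aromatic carbon. Nothing measured here tells how this change acts in this assay; what follows rests on compound 1 and on the change itself. The step expected is a number 5 percentage points lower from compound 1 to compound 3 (within the scatter), small and without a direction that the data would support, and it may well fall inside the scatter of repeated measurements. Compound 3 is expected to give about 40% in this assay, within a range from 20% to 65%.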

Compound 3, a percentage reported as activity, at one concentration (the size of the read-out at that concentration, not a potency): 46%
For compound 3 the middle estimate is 6 percentage points below the measured one, within the range that was stated.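

In this assay, among the compounds shown here, the change from phenyl to 4-bromophenyl gives a number 1 percentage points higher from compound 1 to compound 3 (within the scatter) and is the first step that can be read at all. This aromatic carbon, para to a large group, therefore carries a bromo, one heavy atom in place of a hydrogen, with no readable shift at the one concentration tested, and compound 1 and compound 3 stand level on this read-out. The data at hand hold nothing that explains this result or bears on what the bromo does here.

For the compounds shown here, a single substituent at a single carbon shows only that this one exchange is tolerated on the core of compound 1, not that the position is indifferent to substitution in general, and whether an amine or a carboxylic acid at the same carbon would leave the read-out equally unmoved remains open. Also open, on these data alone, is whether the bromo would behave the same way at another carbon of this ring or on a core with a different substitution pattern, and whether a single concentration hides any difference between the two compounds.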